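Swapping Methyl for Nitro Where Only Bromo Gave a Number

A few compounds are considered here, and "the series" means these few. Any claim that something is new, unique, unknown or untested is made for them only; others in the source may bear on it.

Compound 3, `Cc1ccc(C2=NN(C(=S)Nc3ccccc3)C(c3ccc4c(c3)OCCO4)C2)cc1`, is one of three close relatives tested in a functional assay on HCT-116 cells (Homo sapiens) for antiproliferative activity, read by MTT assay, with a stated time of 48 h; on this read-out lower numbers stand for stronger inhibition of growth and higher numbers for weaker inhibition of growth. In this assay compound 3 gives > 200000 nM, which is a limit of the assay rather than a number. Compound 1, `S=C(Nc1ccccc1)N1N=C(c2ccc(Cl)cc2)CC1c1ccc2c(c1)OCCO2`, also returns a limit in this assay, > 200000 nM. Only compound 2, `S=C(Nc1ccccc1)N1N=C(c2ccc(Br)cc2)CC1c1ccc2c(c1)OCCO2`, gives a real number in this assay, 32100 nM. Compound 3 therefore stands together with compound 1 at the weak end of the set, since the limit of > 200000 nM in this assay, at which 2 of the 3 values shown sit, is where both sit.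

Compound 4, `O=[N+]([O-])c1ccc(C2=NN(C(=S)Nc3ccccc3)C(c3ccc4c(c3)OCCO4)C2)cc1`, carries the change (nitro in place of methyl on an aromatic carbon). Within the data shown here, no measured step involves a nitro group. Among the measured compounds shown here, the steps that bear on this position are an at least 6.2-fold lower number from compound 1 to compound 2 (0.79 log units; beyond the scatter) and an at least 6.2-fold higher number from compound 2 to compound 3 (0.79 log units; beyond the scatter), while a step that the two limits leave unreadable from compound 1 to compound 3. These show that a small change at this carbon can move the read-out by a readable amount in either direction, but they offer no guide for a nitro group itself. Compound 4 is therefore expected to stay close to where compound 3 stands, with an at least 1.3-fold lower number from compound 3 to compound 4 (0.12 log units; that floor lies within the scatter) as the estimated step. Compound 4 is estimated at 150000 nM, with a range from 25000 nM to 200000 nM.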

Compound 4, concentration for 50% growth inhibition: > 200000 nM
Compound 4 ended at the assay's limit; the forecaster's own chance of this, stated with the estimate: 55%; at least 1.3-fold (0.12 log units) between middle value and limit.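

Putting nitro in place of bromo gives an at least 6.2-fold higher number from compound 2 to compound 4 (0.79 log units; beyond the scatter) in this assay, so a group very different from methyl still falls well short of the bromo result. The steps linking compound 4 to compound 1 and to compound 3 cannot be read, as both ends of each are limits. Bromo thus remains the only group at this carbon with a real number, and the set now gathers at its weak end: the limit of > 200000 nM in this assay, at which 3 of the 4 values shown sit.

As far as these compounds go, how far compound 1, compound 3 and compound 4 each lie past that limit stays unknown, so chloro, methyl and nitro cannot be placed in any order. Also open, from the compounds shown here alone, is whether the readable growth inhibition belongs to bromo alone, or whether iodo, an amine or a carboxylic acid at this carbon would also give a real number.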